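A few compounds are considered here, and "the series" means these few. Any claim that something is new, unique, unknown or untested is made for them only; others in the source may bear on it.

Measured compounds:
compound 1, `COc1cc2c(Oc3ccc(NC(=O)c4cn(-c5ccccc5)nn4)cc3F)ccnc2cc1OCCCN1CCCCC1`: 210 nM
compound 2, `COc1cc2c(Oc3ccc(NC(=O)c4cn(-c5ccccc5F)nn4)cc3F)ccnc2cc1OCCCN1CCCCC1`: 210 nM

Both compounds were tested in a functional assay on NCI-H460 cells (Homo sapiens) for cytotoxicity, read by MTT assay, with a stated time of 72 h; a higher number here means a weaker inhibitor, a lower number a stronger inhibitor. Compound 1 gives 210 nM there, and compound 2 gives 210 nM, so compound 2 stands level with compound 1 at the digits shown. Going by the values given here, the only measured step, no change at the digits printed from compound 1 to compound 2 (within the scatter), came with a fluoro in place of hydrogen on an aromatic carbon, and it produced nothing beyond the scatter.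

Compound 3, `COc1cc2c(Oc3ccc(NC(=O)c4cn(-c5ccc(Br)cc5)nn4)cc3F)ccnc2cc1OCCCN1CCCCC1`, has not yet been measured. It differs from compound 2 as follows: 4-bromophenyl in place of 2-fluorophenyl on an aromatic nitrogen. Among the compounds with values here, this is a larger alteration than the measured step, since the ring that sits on the triazole nitrogen now carries bromine rather than fluorine and at a different position of the ring, so the single measured step bears on it only loosely. With that step showing no change, the expectation for compound 3 is a step of a 1.2-fold higher number from compound 2 to compound 3 (0.08 log units; within the scatter) in this assay, that is, no shift beyond the scatter, with the uncertainty widened to allow for the bulkier halogen. Compound 3 is therefore estimated at 250 nM, with a range from 100 nM to 700 nM.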

Compound 3, half-maximal inhibitory concentration: 360 nM
Beside the measured number, compound 3's estimate is 1.4-fold (0.16 log units) below it; measured number inside the range.
By their numbers in this assay, from the lowest: compounds 1, 2 and 3 (each within the scatter of the next).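

In this assay, 4-bromophenyl in place of 2-fluorophenyl on the aromatic nitrogen gives a 1.7-fold higher number from compound 2 to compound 3 (0.23 log units; within the scatter), and bromo in place of hydrogen on the unsubstituted phenyl gives a 1.7-fold higher number from compound 1 to compound 3 (0.23 log units; within the scatter). The earlier pair had tried only a fluoro group here, so these steps add a second halogen, bromine, in a different place on the phenyl ring, and both steps lie within the scatter, which means that this assay cannot tell the three compounds apart. No measurement shown here bears on what lies behind these numbers.

Going by these compounds, the step from compound 2 to compound 3 changes the halogen and its place on the ring together, so the effect of each remains open, and a 4-fluorophenyl or a 2-bromophenyl group would separate the two. Also open, on these data alone, is how this position responds to groups of a different kind, such as an amine or a carboxylic acid on the phenyl ring, or a benzyl group in place of the phenyl.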